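Working notes: a smaller group on the aromatic nitrogen

A few compounds are considered here, and "the series" means these few. Any claim that something is new, unique, unknown or untested is made for them only; others in the source may bear on it.

Measured compounds:
compound 1 `O=C(C1CC1)N1CCN(Cc2nc3ccccc3n2Cc2ccccc2C(F)(F)F)CC1` gives 56.3% in an assay on isolated protein for inhibition of aldehyde dehydrogenase 1A1 (Homo sapiens), read by spectrophotometry, tested at 10 uM; on this read-out lower numbers stand for less inhibition and higher numbers for more inhibition at the one concentration tested (going by the name of the read-out)
compound 2 `CC(C)CCn1c(OC2CCN(C(=O)c3ccco3)CC2)nc2ccccc21` gives 30.8%
compound 3 `Cc1cccc(Cn2c(CN3CCN(C(=O)c4ccc(C#N)cc4)CC3)nc3ccccc32)c1` gives 20.8%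

Compound 1 stands highest of the three numbers; compound 2 lies nearest to it and compound 3 furthest, and both gaps are beyond the scatter. Compound 4 `O=C(C1CC1)N1CCN(Cc2nc3ccccc3n2CC2CC2)CC1` is not yet measured. Its change from compound 1 is cyclopropyl in place of 2-(trifluoromethyl)phenyl on a saturated chain carbon bound to an aromatic nitrogen. For the measured compounds named here, no measured pair in this set differs in only one place, so the size of such a step has not been seen here. A downward step in this assay from compound 1 to compound 4 is expected, beyond the scatter, as a number 21.3 percentage points lower from compound 1 to compound 4 (beyond the scatter). Compound 4 is therefore estimated at 35%, in a range from 15% to 55%.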

Compound 4, a percentage reported as inhibition, at one concentration (the size of the read-out at that concentration, not a potency): 21.2%
Estimate against measurement, compound 4: 13.8 percentage points above, and the stated range covers the measured number.
By their numbers in this assay, from the lowest: compounds 3, 4 and 2 (each within the scatter of the next); then compound 1.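

This gives the series its first step in one place: in this assay, cyclopropyl in place of 2-(trifluoromethyl)phenyl on a saturated chain carbon bound to an aromatic nitrogen gives a number 35.1 percentage points lower from compound 1 to compound 4 (beyond the scatter). The read-out therefore responds strongly to the group at this position, with the rest of compound 1 unchanged. Nothing measured accounts for the size of this step.

On these data alone, it stays open whether the step follows the aromatic ring or the trifluoromethyl group. A plain phenyl at the same place would separate the two.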